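From carboxy to phenoxy: compound 3 to compound 4

A few compounds are considered here, and "the series" means these few. Any claim that something is new, unique, unknown or untested is made for them only; others in the source may bear on it.

In a functional assay on KB-V1 cells (Homo sapiens) for cytotoxicity, read by MTT assay, with a stated time of 72 h (on this read-out lower numbers stand for stronger inhibition and higher numbers for weaker inhibition), compound 1 (`O=C1Nc2ccccc2/C1=N/NC(=S)Nc1ccccc1`) gives 1470 nM and compound 2 (`O=C1Nc2ccccc2/C1=N/NC(=S)Nc1ccc(F)cc1`) gives 1920 nM. Compound 3 (`O=C1Nc2ccccc2/C1=N/NC(=S)Nc1ccc(C(=O)O)cc1`) reads > 50000 nM, which is a limit and not a number.

Compound 4 (`O=C1Nc2ccccc2/C1=N/NC(=S)Nc1ccc(Oc2ccccc2)cc1`) carries phenoxy in place of carboxy on an aromatic carbon, para to a large group: phenoxy in place of carboxy on an aromatic carbon.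

Carboxy in place of hydrogen gave an at least 34-fold higher number from compound 1 to compound 3 (1.53 log units; beyond the scatter), and carboxy in place of fluoro gave an at least 26-fold higher number from compound 2 to compound 3 (1.41 log units; beyond the scatter), both large. Fluoro in place of hydrogen gave a 1.3-fold higher number from compound 1 to compound 2 (0.12 log units; within the scatter). Among the measured compounds shown here, no measured compound carries phenoxy, so the expectation rests on the loss of carboxy. A large step to a lower number is expected, estimated as an at least 50-fold lower number from compound 3 to compound 4 (1.69 log units; beyond the scatter). For compound 4 the estimate is 1000 nM, with an expected range of 300 nM to 3500 nM.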

Compound 4, half-maximal inhibitory concentration: 1670 nM
Compound 4: middle estimate off by 1.7-fold (0.22 log units), on the low side; low and high end bracket the measured number.
By their numbers in this assay, from the lowest: compounds 1, 4 and 2 (each within the scatter of the next). At a limit, above all of these: compound 3.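

Phenoxy, with its seven heavy atoms and aromatic ring, sits level with hydrogen and fluoro at this position, para to a large group: a 1.1-fold higher number from compound 1 to compound 4 (0.06 log units; within the scatter) and a 1.1-fold lower number from compound 2 to compound 4 (0.06 log units; within the scatter). The heavy-atom count of the group therefore does not sort these compounds, and among the four only carboxy stands apart, with an at least 29-fold lower number from compound 3 to compound 4 (1.47 log units; beyond the scatter). Compound 3 reads as a limit and not a number: the limit of > 50000 nM in this assay, at which 1 of the 4 values shown sits.

From the compounds shown here alone, whether an amine, a methyl ester or a hydroxy group here would read with compound 3 or with compounds 1, 2 and 4 stays open. Going by these compounds, the full size of the carboxy step also stays open.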